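An amide substituent change on a shared core

The compounds below may be only part of what the source reports. "The series", "measured", "known", "first", "only" and "open" are said of these compounds alone.

Of the compounds shown here, three sharing one core have been tested in a functional assay on A549 cells (Homo sapiens) for cytotoxicity, read by MTT assay, with a stated time of 24 h; on this read-out higher numbers stand for weaker inhibition and lower numbers for stronger inhibition. Compound 1 `C=CC1=C(C(=O)Nc2ccccc2OC)C(c2ccc(F)cc2)OC1` gives > 100000 nM, which is a limit of the assay rather than a number. Compound 2 `C=CC1=C(C(=O)NCc2ccccc2)C(c2ccc(Cl)c(Cl)c2)OC1` gives > 100000 nM, again only a limit. Compound 3 `C=CC1=C(C(=O)NCCC)C(c2ccc(Cl)c(Cl)c2)OC1` gives > 100000 nM, also a limit, so compound 3 stands at the edge of what this assay can report, as do the other two. Going by the values given here, the one comparison between measured compounds, a step that the two limits leave unreadable from compound 2 to compound 3, cannot be read because the limit of > 100000 nM in this assay, at which 3 of the 3 values shown sit, holds both of its values.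

Compound 4 `C=CC1=C(C(=O)Nc2ccccc2OC)C(c2ccc(Cl)c(Cl)c2)OC1` has not yet been tested. It differs from compound 3 by 2-methoxyphenyl in place of propyl on an amide-type nitrogen. Among the compounds with values here, no measured step speaks to this change, and the group that enters already sits on compound 1, which is at the limit. Compound 4 is therefore expected to show no step beyond the scatter, with an estimated step that the limit leaves unreadable from compound 3 to compound 4, and to give an estimated 150000 nM in this assay, within the range 60000 nM to 400000 nM, most likely reported only as a limit.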

Compound 4, half-maximal inhibitory concentration: > 100000 nM
Compound 4 ended at the assay's limit; the forecaster's own chance of this, stated with the estimate: 85%; the middle value is on the limit's open side.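

No step from compound 1, compound 2 or compound 3 to compound 4 can be read, because all four compounds give only the same limit and no number: the limit of > 100000 nM in this assay, at which 4 of the 4 values shown sit. The compounds shown leave open whether changing the amide substituent has any effect on potency in this assay.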